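Branching the Carbamate Chain of Compound 3

This account rests on a few compounds, and the source may have more. Where it says the series, first, only, none or still open, it means among the compounds named here.

The measured compounds and their values in a functional assay (Oryctolagus cuniculus) for inhibition of platelet-activating factor receptor (Cavia porcellus); on this read-out lower numbers stand for stronger inhibition and higher numbers for weaker inhibition:
Compound 1 `CCCCCC(=O)OCC1CN(C(=O)c2cc(OC)c(OC)c(OC)c2)CCN1C(=O)c1cc(OC)c(OC)c(OC)c1`: 290 nM
Compound 2 `CCCCCCCCCC(=O)OCC1CN(C(=O)c2cc(OC)c(OC)c(OC)c2)CCN1C(=O)c1cc(OC)c(OC)c(OC)c1`: 2820 nM
Compound 3 `CCCC(C)NC(=O)OCC1CN(C(=O)c2cc(OC)c(OC)c(OC)c2)CCN1C(=O)c1cc(OC)c(OC)c(OC)c1`: 100 nM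

All three share the same core and differ only in the group attached through an oxygen-bound carbonyl. Compound 3, carrying a (1-methylbutyl)amino group on that carbonyl, gives the lowest number of the three. Its nearest neighbour is compound 1, with a 2.9-fold lower number from compound 1 to compound 3 (0.46 log units; beyond the scatter); compound 2 is furthest, with a 28-fold lower number from compound 2 to compound 3 (1.45 log units; beyond the scatter). Among the esters, lengthening the chain weakened inhibition: a 9.7-fold higher number from compound 1 to compound 2 (0.99 log units; beyond the scatter).

Compound 4 `COc1cc(C(=O)N2CCN(C(=O)c3cc(OC)c(OC)c(OC)c3)C(COC(=O)NC(C)C(C)C)C2)cc(OC)c1OC` keeps the carbamate of compound 3 but rearranges its alkyl part: isopropyl in place of propyl on a saturated chain carbon bound to an amide-type nitrogen and a saturated chain carbon. The two compounds contain the same atoms joined differently.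

For the measured compounds named here, no measured step concerns such a branching; the measured steps report chain length in the ester series and the switch from ester to carbamate, both beyond the scatter but of a different kind. The change from propyl to isopropyl does not alter the count of atoms, so a step no larger than the scatter, or a modest one, is the expectation. Compound 4 is therefore expected to give about 130 nM, between 55 nM and 320 nM, corresponding to an estimated step of a 1.3-fold higher number from compound 3 to compound 4 (0.11 log units; within the scatter).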

Compound 4, half-maximal inhibitory concentration: 80 nM
Beside the measured number, compound 4's estimate is 1.6-fold (0.21 log units) above it, and the stated range covers the measured number.
By their numbers in this assay, from the lowest: compounds 4 and 3 (each within the scatter of the next); then compound 1; then compound 2.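

In this assay, rearranging the carbamate's alkyl part from 1-methylbutyl to 1,2-dimethylpropyl gives a 1.3-fold lower number from compound 3 to compound 4 (0.10 log units; within the scatter), so at this place, on a saturated chain carbon bound to an amide-type nitrogen and a saturated chain carbon, isopropyl and propyl cannot be told apart from ordinary repeat variation. The gap to the esters survives the rearrangement, with a 3.6-fold lower number from compound 1 to compound 4 (0.56 log units; beyond the scatter) and a 35-fold lower number from compound 2 to compound 4 (1.55 log units; beyond the scatter), so the two differently branched carbamates both stand clear of the two esters, and neither goes against that. Nothing available explains why the two carbamates read alike.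

The compounds shown leave open how a straight pentylamino group on the same carbonyl would compare with these two branched groups, so the contribution of branching itself cannot yet be read. They also leave open whether a ring such as cyclohexyl, a more compact group such as tert-butyl, or a carboxylic acid or an amine at the end of the chain would keep inhibition at this level.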